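The source may hold more compounds than are shown below. What is called first, only, known or untested is meant among the compounds shown, and "the series" means these compounds.

Compound 1 `Cc1cccc(C(=O)OC(CCN(C)C)c2ccc(Cl)cc2)c1C` gives 91% in an assay on NIH3T3 cells with Urotensin-2 receptor (Homo sapiens) as the target; on this read-out lower numbers stand for smaller maximal responses and higher numbers for larger maximal responses.
Compound 2 `COc1cccc(C(=O)OC(CCN(C)C)c2ccc(Cl)cc2)c1C` gives 88% in this assay.
Compound 3 `Cc1c(Cl)cccc1C(=O)OC(CCN(C)C)c1ccc(Cl)cc1` gives 118% in this assay.

Compound 3 stands highest of the three: a number 27 percentage points higher from compound 1 to compound 3 (beyond the scatter) and a number 30 percentage points higher from compound 2 to compound 3 (beyond the scatter), whereas a number 3 percentage points lower from compound 1 to compound 2 (within the scatter). Compound 4 `Cc1ccccc1NC(=O)OC(CCN(C)C)c1ccc(Cl)cc1` has not been measured; it differs from compound 3 by (2-methylphenyl)amino in place of 3-chloro-2-methylphenyl on a carbonyl carbon. Within the data shown here, no measured step exchanges a group on the carbonyl carbon, so that part of the change has no precedent here. What does bear on it is the loss of the chloro: because a number 27 percentage points higher from compound 1 to compound 3 (beyond the scatter) and a number 30 percentage points higher from compound 2 to compound 3 (beyond the scatter) both showed the chloro raising the response, compound 4, which no longer carries it, is expected to move by a number 28 percentage points lower from compound 3 to compound 4 (beyond the scatter) in this assay. The estimate for compound 4 is 90%, between 60% and 115%.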

Compound 4, largest response reached (reported as efficacy), in percent of the reference or control that the assay uses: 176%
Compound 4: middle estimate off by 86 percentage points, on the low side; the whole stated range lies below it.
By their numbers in this assay, from the lowest: compounds 2 and 1 (each within the scatter of the next); then compound 3; then compound 4.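

Putting (2-methylphenyl)amino on the carbonyl carbon brings in a hydrogen-bond donor and gives a large rise, a number 58 percentage points higher from compound 3 to compound 4 (beyond the scatter) and a number 85 percentage points higher from compound 1 to compound 4 (beyond the scatter) in turn. This place therefore moves the response more than the modest chloro steps did, and the chloro of the 3-chloro-2-methylphenyl group is not needed for a high response. Nothing measured here explains the rise.

Going by these compounds, whether the gain depends on the aromatic ring of the new group stays open. A cyclohexylamino or methylamino group on the carbonyl carbon would test this.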